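A few compounds are considered here, and "the series" means these few. Any claim that something is new, unique, unknown or untested is made for them only; others in the source may bear on it.

Compounds measured in a functional assay on MOLT-4 cells (Homo sapiens) for inhibition, read by sulforhodamine B assay, with a stated time of 48 h; a lower number here means a stronger inhibitor of growth, a higher number a weaker inhibitor of growth:
compound 1 `COc1cc(-c2cc(/C=C/C(=O)c3ccc(N)cc3)[nH]n2)cc(OC)c1OC` gives 1910 nM
compound 2 `COc1ccc(C(=O)/C=C/c2cc(-c3cc(OC)c(OC)c(OC)c3)n[nH]2)cc1OC` gives 2110 nM
compound 3 `COc1ccc(C(=O)/C=C/c2cc(-c3cc(OC)c(OC)c(OC)c3)n[nH]2)cc1` gives 2670 nM

Among these three numbers compound 3 sits at the top end, yet the gaps are small: a 1.4-fold higher number from compound 1 to compound 3 (0.15 log units; within the scatter) and a 1.3-fold higher number from compound 2 to compound 3 (0.10 log units; within the scatter) are both within the scatter, so none of the three compounds can be set apart from the others by these data.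

Compound 4 `COc1cc(-c2cc(/C=C/C(=O)c3ccc(F)c(F)c3)[nH]n2)cc(OC)c1OC` has not yet been measured. It differs from compound 3 in one place: 3,4-difluorophenyl in place of 4-methoxyphenyl on a carbonyl carbon. All three measured steps bear on this change, since each of them also swaps or trims the group on that carbonyl carbon while the rest of the molecule stays the same. They were a 1.1-fold higher number from compound 1 to compound 2 (0.04 log units; within the scatter), a 1.4-fold higher number from compound 1 to compound 3 (0.15 log units; within the scatter) and a 1.3-fold higher number from compound 2 to compound 3 (0.10 log units; within the scatter), and every one of them stayed within the scatter. On that basis, in this assay compound 4 is expected to show no step beyond the scatter, the estimated step being a 1.0-fold higher number from compound 3 to compound 4 (0.02 log units; within the scatter). The estimate for compound 4 in this assay is therefore 2800 nM, with a range from 1200 nM to 6500 nM.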

Compound 4, concentration for 50% growth inhibition: 2720 nM
Compound 4: the middle estimate sits 1.0-fold (0.01 log units) above what was measured; low and high end bracket the measured number.
By their numbers in this assay, from the lowest: compounds 1, 2, 3 and 4 (each within the scatter of the next).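

In this assay, 3,4-difluorophenyl on the carbonyl carbon gives a 1.0-fold higher number from compound 3 to compound 4 (0.01 log units; within the scatter) when it replaces 4-methoxyphenyl, a 1.3-fold higher number from compound 2 to compound 4 (0.11 log units; within the scatter) when it replaces 3,4-dimethoxyphenyl and a 1.4-fold higher number from compound 1 to compound 4 (0.15 log units; within the scatter) when it replaces 4-aminophenyl. The earlier compounds shown here carried only oxygen or nitrogen substituents on this phenyl ring, whereas compound 4 carries fluorine and, by the count for the groups that were swapped, has no hydrogen-bond acceptor in this group where compound 3 has one; even this swap leaves the number within the scatter, so four different substituted phenyl groups at this place cannot be told apart by these data. No measurement is available that would explain why these groups read alike.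

Going by these compounds, all four compounds keep a substituted phenyl ring on the carbonyl carbon, so it remains open whether a carboxylic acid or a dimethylamino group on that ring, or a cyclohexyl ring or a longer alkyl chain in place of the phenyl ring, would also stay within the scatter. On these data alone, the shared core stays the same throughout, so what changes there would do also remains open.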